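The source may report more compounds than this note shows. Statements on the series, on what has been measured and on what is new or still open speak of the compounds shown alone.

Among the measured compounds shown here, compound 1 `Cc1n[nH]c(C(=O)O)c1Cc1ccccc1Oc1ccccc1` stands highest of the two numbers so far in an assay on isolated protein for inhibition of 2-Hydroxyacid oxidase 2 (Homo sapiens), tested at 10 uM (a lower number here means a weaker effect, a higher number a stronger effect of the compound at the concentration tested), where compound 1 gives 49%. For the measured compounds named here, the only other compound measured, compound 2 `Cc1c(Cc2cccc(-c3ccc(F)cc3)c2)c(C(=O)O)nn1C`, gives 4% in this assay, and the gap between these two values lies beyond the usual scatter. Going by the values given here, the two differ in several places at once, so no single-change step between measured compounds is available to calibrate the next move, and the size of that move can only be guessed.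

The next compound, compound 3 `Cc1n[nH]c(C(=O)O)c1Cc1ccccc1C(F)(F)F`, keeps the core of compound 1 and changes one group: trifluoromethyl in place of phenoxy on an aromatic carbon. Among the compounds with values here, since no measured step of this kind exists, the expectation rests only on the standing of compound 1 and on the smaller group that enters. A moderate loss of inhibition is expected here, with the step from compound 1 to compound 3 estimated at a number 24 percentage points lower from compound 1 to compound 3 (beyond the scatter), a step that would lie beyond the scatter but need not. Compound 3 is accordingly estimated at 25% in this assay, within a range from 5% to 50%.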

Compound 3, a percentage reported as inhibition, at one concentration (the size of the read-out at that concentration, not a potency): 38%
Estimate against measurement, compound 3: 13 percentage points below; the range from low to high includes it.
By their numbers in this assay, from the lowest: compound 2; then compound 3; then compound 1.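

In this assay, the series gains its first single-change comparison, a number 11 percentage points lower from compound 1 to compound 3 (beyond the scatter), with trifluoromethyl in place of phenoxy on an aromatic carbon, ortho to a large group. The loss is modest, and a measurable effect remains without the six-membered aromatic ring of phenoxy or its oxygen, as compound 3 still gives 38% at the single concentration tested, so inhibition at this position does not depend entirely on the phenoxy group. No measurement bearing on the origin of this step is available, so it stands as an observation only.

The compounds shown leave open whether a methoxy group, a chlorine atom or an amine on this same carbon would keep inhibition near the level of compound 1 or compound 3, and whether a benzyloxy group, with its longer link to the ring, would exceed that of compound 1. They also leave open how the step divides between the ring and the oxygen of phenoxy, a question that a benzyl group on this carbon would help to separate.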